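The source may hold more compounds than are shown below. What is called first, only, known or untested is meant among the compounds shown, and "the series" means these compounds.

Compound 1 `CCCN1CCC(CCCn2c(COc3ccc(Cl)cc3)nc3c(C)cccc32)CC1` gives 29 nM in an assay on AV12 cells for binding affinity to Neuropeptide Y receptor type 1 (Homo sapiens); on this read-out higher numbers stand for weaker inhibition and lower numbers for stronger inhibition; compound 2 `Cc1cccc2c1nc(COc1ccc(Cl)cc1)n2CCCC1CCN(CCC(C)C)CC1` gives 11 nM in this assay, and compound 3 `Cc1cccc2c1nc(COc1ccc(Cl)cc1)n2CCCC1CCN(CCCc2ccccc2)CC1` gives 57 nM, the highest of the three numbers. The steps into compound 3 are a 2.0-fold higher number from compound 1 to compound 3 (0.29 log units; within the scatter) and a 5.2-fold higher number from compound 2 to compound 3 (0.71 log units; beyond the scatter); between the two smaller chains the step is a 2.6-fold lower number from compound 1 to compound 2 (0.42 log units; beyond the scatter). Compound 4 `CCOC(=O)CN1CCC(CCCn2c(COc3ccc(Cl)cc3)nc3c(C)cccc32)CC1` differs from compound 3 by ethoxycarbonyl in place of phenethyl on a saturated chain carbon bound to an amine nitrogen in a ring. Among the compounds with values here, all variation so far sits on this same chain, and both measured steps toward shorter chains read downward from compound 3, though only one lies beyond the scatter. No ester has been measured in this assay, so the precedent is thin. Compound 4 is therefore expected to show a modest fall in this assay, a 1.6-fold lower number from compound 3 to compound 4 (0.21 log units; within the scatter), to about 35 nM, with a range from 10 nM to 130 nM.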

Compound 4, inhibition constant: 427 nM
Compound 4: middle estimate off by 12-fold (1.09 log units), on the low side; the whole stated range lies below it.
By their numbers in this assay, from the lowest: compound 2; then compounds 1 and 3 (each within the scatter of the next); then compound 4.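

In this assay the chains of carbon only at this position span a smaller range, the widest gap being a 5.2-fold higher number from compound 2 to compound 3 (0.71 log units; beyond the scatter) in that set, while ethoxycarbonyl stands apart with a 7.5-fold higher number from compound 3 to compound 4 (0.87 log units; beyond the scatter) and a 15-fold higher number from compound 1 to compound 4 (1.17 log units; beyond the scatter) and a 39-fold higher number from compound 2 to compound 4 (1.59 log units; beyond the scatter) on the same read-out. Nothing available accounts for this separation. Still open, going by these compounds, is whether the rise follows the ester itself or any oxygen on this chain; an ether chain, an amide or a carboxylic acid in the same place would tell these apart.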